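The source may report more compounds than this note shows. Statements on the series, on what has been measured and on what is new or still open speak of the compounds shown alone.

Compound 1 `Cc1ccccc1C(=O)Nc1ccc(S(=O)(=O)NC2CCN(C(=O)C3CNC3)CC2)c2ccccc12`: 1.5 nM. Compound 2 `Cc1ccccc1C(=O)Nc1ccc(S(=O)(=O)NC2CCN(C(=O)[C@@H]3CCCN3)CC2)c2ccccc12`: 0.7 nM; 1 nM (2 entries).

Compound 1 carries a single measurement in an assay on L1.2 cells for binding affinity to C-C chemokine receptor type 8 (Homo sapiens); a lower number here means a stronger inhibitor, a higher number a weaker inhibitor; it sits within the usual scatter of the several values of compound 2 (the several entries of compound 2 in this assay, 0.7 nM; 1 nM (2 entries)), so no order can be read between the two. Compound 3 `Cc1ccccc1C(=O)Nc1ccc(S(=O)(=O)NC2CCN(C(=O)N3CCOCC3)CC2)c2ccccc12` has not yet been measured in this assay. It differs from compound 1 by morpholin-4-yl in place of azetidin-3-yl on a carbonyl carbon. Within the data shown here, the change trades a group with one hydrogen-bond donor for one with none, and no measured pair covers such a swap here, so the size of the step is uncertain; a modest weakening, somewhat beyond the scatter, is expected, a 4.0-fold higher number from compound 1 to compound 3 (0.60 log units; beyond the scatter). Compound 3 is estimated at 6 nM, with a range from 1.5 nM to 25 nM.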

Compound 3, inhibition constant: 6.3 nM
The estimate for compound 3 lay 1.1-fold (0.02 log units) below the measured number; low and high end bracket the measured number.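

In this assay, among these compounds, the swap to morpholin-4-yl gives a 4.2-fold higher number from compound 1 to compound 3 (0.62 log units; beyond the scatter) and so offers the first readable step on this carbonyl carbon. The group here therefore affects the number, yet one step cannot say which difference between the two groups is responsible. Repeat readings offer a yardstick for judging such a step: the several entries of compound 2 in this assay, 0.7 nM; 1 nM (2 entries)

Still open, from the compounds shown here alone, is whether ring size, the ring oxygen or the hydrogen-bond donor matters most. Piperidin-1-yl, which has no ring oxygen, and pyrrolidin-1-yl on the same carbonyl carbon would help separate these differences.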